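The source may hold more compounds than are shown below. What is called first, only, known or untested is meant among the compounds shown, and "the series" means these compounds.

Measured series in a functional assay for inhibition, with Homo sapiens as the target; a lower number here means a stronger inhibitor, a higher number a weaker inhibitor:
compound 1 `O=C(O)COc1cccc(CCc2nc(-c3ccccc3)c(-c3ccccc3)o2)c1`: 1200 nM
compound 2 `O=C(O)COc1cccc(/C=C(\C(=O)O)c2nc(-c3ccccc3)c(-c3ccccc3)o2)c1`: 20300 nM
compound 3 `CC(C)OC(=O)C(Cc1cccc(OCC(=O)O)c1)c1nc(-c2ccccc2)c(-c2ccccc2)o1`: 1220 nM

Compound 3 stands second highest of the three numbers; its nearest is compound 1, within the scatter, and its furthest is compound 2, which lies beyond the scatter. Compound 4 `O=C(O)COc1cccc(CC(CCCCO)c2nc(-c3ccccc3)c(-c3ccccc3)o2)c1` differs from compound 3 by 4-hydroxybutyl in place of isopropoxycarbonyl on a saturated chain carbon bound to an aromatic carbon and a saturated chain carbon. Among the measured compounds shown here, the one measured step that bears on this position is a 1.0-fold higher number from compound 1 to compound 3 (0.01 log units; within the scatter), which shows that placing a group on this saturated chain carbon left the number in this assay unchanged. For the measured compounds named here, no step links compound 2 to the others. On that basis the expected step is a 1.0-fold lower number from compound 3 to compound 4 (0.01 log units; within the scatter), none beyond the scatter. Compound 4 is therefore estimated at 1200 nM, range 500 nM to 3000 nM.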

Compound 4, half-maximal inhibitory concentration: 4680 nM
Estimate against measurement, compound 4: 3.9-fold (0.59 log units) below; the measured number lies above the stated range.
By their numbers in this assay, from the lowest: compounds 1 and 3 (each within the scatter of the next); then compound 4; then compound 2.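

In this assay this saturated chain carbon proves sensitive to what it carries: 4-hydroxybutyl in place of isopropoxycarbonyl gives a 3.8-fold higher number from compound 3 to compound 4 (0.58 log units; beyond the scatter) and 4-hydroxybutyl in place of hydrogen gives a 3.9-fold higher number from compound 1 to compound 4 (0.59 log units; beyond the scatter) while isopropoxycarbonyl in place of hydrogen stayed within the scatter. The tolerance seen with compound 3 therefore does not extend to every group at this place. Nothing measured here accounts for the difference between the two groups.

Going by these compounds, whether the weaker number belongs to the hydroxy group or to the butyl chain stays open. A plain butyl chain, a shorter hydroxyalkyl chain or an aminobutyl group would separate these.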